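A Ring Swap on the Side Chain of Compound 1

The source may hold more compounds than are shown below. What is called first, only, known or untested is meant among the compounds shown, and "the series" means these compounds.

Compound 1 `CN(C)CCCNc1nc(N)nc2cc(-c3ccc(C(F)(F)F)cc3)sc12` in an ADME assay (liver) for metabolic stability, with Liver microsome (Homo sapiens) as the target, read by LC-MS, using microsomes, tested at 0.1 uM (a higher number here means that the compound lasts longer, a lower number that the compound disappears faster), gives 1.73 h as a measured number
Compound 2 `COc1nc(NCCCN(C)C)c2sc(-c3ccc(C(F)(F)F)cc3)cc2n1` in this assay gives > 1.66 h as a limit of the assay
Compound 3 `CN(C)CCCNc1nc(N2CCNCC2)nc2cc(-c3ccc(C(F)(F)F)cc3)sc12` in this assay gives > 1.66 h as a limit of the assay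

Within the data shown here, compound 1 carries the only true number in this small set. Compound 2 and compound 3 stand at the limit of > 1.66 h in this assay, at which 2 of the 3 values shown sit, and give no number of their own.

The change to compound 4 `Nc1nc(N2CCC(N)CC2)c2sc(-c3ccc(C(F)(F)F)cc3)cc2n1` is 4-aminopiperidin-1-yl in place of (3-(dimethylamino)propyl)amino on an aromatic carbon and it puts 4-aminopiperidin-1-yl in place of (3-(dimethylamino)propyl)amino on an aromatic carbon. The open chain gives way to a six-membered non-aromatic ring.

The measured steps are a step that the limit leaves unreadable from compound 1 to compound 2 and a step that the limit leaves unreadable from compound 1 to compound 3 and both replace the amino group, not the chain that changes here. Neither offers a size to carry over. Compound 1 at 1.73 h is therefore the only anchor. The expected change is a 1.0-fold lower number from compound 1 to compound 4 (0.01 log units; within the scatter) and it is expected to stay within the usual scatter, in no particular direction. In this assay the expected value for compound 4 is 1.7 h with an estimated range from 0.85 h to 3.4 h for now.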

Compound 4, half-life: > 2.5 h
Compound 4: only a limit was reported; the forecaster's own chance of this, stated with the estimate: 50%; middle value at least 1.4-fold (0.16 log units) away from the limit.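

Compound 4 is the only compound shown that changes the (3-(dimethylamino)propyl)amino group rather than the amino group, and in this assay compound 4 gives only a limit of the assay: the limit of > 2.5 h in this assay, at which 1 of the 4 values shown sits. Set against the measured number of compound 1, this limit gives an at least 1.4-fold higher number from compound 1 to compound 4 (0.15 log units; that floor lies within the scatter). Swapping the open chain for a six-membered non-aromatic ring at this position therefore brought no visible loss of half-life, although the true size of the step remains unknown.

The steps among compounds 1, 2 and 3 cannot be read, so they give no size to compare with this one. On these data alone, it also stays open how a morpholin-4-yl ring, a piperidin-1-yl ring without its amine, or a longer amino chain would behave at this position.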